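From a Piperidinyl Urea to a Difluorocyclohexyl Amide

A few compounds are considered here, and "the series" means these few. Any claim that something is new, unique, unknown or untested is made for them only; others in the source may bear on it.

Measured so far:
compound 1 `CC1CCCCC1C(=O)N1CC(c2nc(-c3cccc(F)c3)no2)C1` — > 10000 nM
compound 2 `O=C(N1CCCCC1)N1CC(c2nc(-c3cccc(Cl)c3)no2)C1` — > 10000 nM
compound 3 `O=S(=O)(c1ccc(F)cc1)N1CC(c2nc(-c3cccc(Cl)c3)no2)C1` — 130 nM

Of the compounds shown here, three on a shared core have been tested in an assay on HEK293 cells for negative allosteric modulation of metabotropic glutamate receptor 5 (Homo sapiens), read by FLIPR; on this read-out higher numbers stand for weaker inhibition and lower numbers for stronger inhibition. The result for compound 2 is a limit of the assay and not a number. Among the compounds with values here, compound 2 therefore stands at the limit of > 10000 nM in this assay, at which 2 of the 3 values shown sit, and the only numeric value among the three belongs to compound 3, the sulfonamide. Compound 1, a cycloalkyl amide, also sits at that limit.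

The next compound, compound 4 `O=C(C1CCC(F)(F)CC1)N1CC(c2nc(-c3cccc(Cl)c3)no2)C1`, differs from compound 2 by 4,4-difluorocyclohexyl in place of piperidin-1-yl on a carbonyl carbon. Within the data shown here, no step between two measured compounds is recorded, so the size of this step in this assay cannot be read from earlier pairs. Compound 1 shows that a cycloalkyl amide on this core can sit at the limit, and compound 4 is expected to behave in the same way, so the step from compound 2 to compound 4 is expected to be none beyond the scatter a step that the limit leaves unreadable from compound 2 to compound 4. Compound 4 is estimated at 15000 nM, within 3000 nM to 50000 nM.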

Compound 4, half-maximal inhibitory concentration: > 10000 nM
Compound 4 was reported as a limit; the forecaster's own chance of this, stated with the estimate: 65%; the middle value is on the limit's open side.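

Compound 2 and compound 4 are both reported as limits in this assay, and no step between them can be read: the limit of > 10000 nM in this assay, at which 3 of the 4 values shown sit.

The compounds shown leave open whether any group on a carbonyl carbon of the shared core can give a numeric value in this assay.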